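The source may hold more compounds than are shown below. What is called first, only, known or untested is meant among the compounds shown, and "the series" means these compounds.

Compound 3 `COC1CCN(c2nc(C(F)(F)F)ccc2CNC(=O)C(C)c2ccc(NS(C)(=O)=O)c(F)c2)CC1` gives 2.4 nM in a functional assay on CHO-K1 cells for antagonist activity at transient receptor potential cation channel subfamily V member 1 (Homo sapiens), read by FLIPR (on this read-out lower numbers stand for stronger inhibition and higher numbers for weaker inhibition), and stands second highest of the three numbers measured; compound 1 `CC(C(=O)NCc1ccc(C(F)(F)F)nc1N1CCC(Cc2cc(F)cc(F)c2)CC1)c1ccc(NS(C)(=O)=O)c(F)c1` gives 0.4 nM and compound 2 `CC(C(=O)NCc1ccc(C(F)(F)F)nc1N1CCC(C(=O)c2ccc(F)cc2)CC1)c1ccc(NS(C)(=O)=O)c(F)c1` gives 3.9 nM. Compound 4 `CC(C(=O)NCc1ccc(C(F)(F)F)nc1N1CCC(OC(=O)C(C)(C)C)CC1)c1ccc(NS(C)(=O)=O)c(F)c1` differs from compound 3 by (tert-butyl)carbonyl in place of methyl on an oxygen on a saturated carbon. Among the measured compounds shown here, two measured steps bear on the same saturated ring carbon: a 6.0-fold higher number from compound 1 to compound 3 (0.78 log units; beyond the scatter) and a 1.6-fold lower number from compound 2 to compound 3 (0.21 log units; within the scatter). The step from compound 1 is modest, that from compound 2 within the scatter, so a larger group at this position has at most lowered the number moderately. For compound 4, with its entering (tert-butyl)carbonyl, a step of a 1.2-fold lower number from compound 3 to compound 4 (0.08 log units; within the scatter) is expected, small and within the scatter. Compound 4 is estimated at 2 nM in this assay, with a range of 0.6 nM to 7 nM.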

Compound 4, inhibition constant: 2 nM
Compound 4: middle estimate and measured number agree at the digits printed; measured number inside the range.
By their numbers in this assay, from the lowest: compound 1; then compounds 4, 3 and 2 (each within the scatter of the next).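

In this assay the larger (tert-butyl)carbonyl on the oxygen changes little, with a 1.2-fold lower number from compound 3 to compound 4 (0.08 log units; within the scatter). The ((tert-butyl)carbonyl)oxy and (4-fluorophenyl)carbonyl groups also read alike on the saturated ring carbon, with a 2.0-fold lower number from compound 2 to compound 4 (0.29 log units; within the scatter), whereas 3,5-difluorobenzyl stays apart, with a 5.0-fold higher number from compound 1 to compound 4 (0.70 log units; beyond the scatter). No supporting evidence is available to explain these readings.

Open, from the compounds shown here alone, is whether an amine or a carboxylic acid on this saturated ring carbon would read like compounds 2, 3 and 4 or like compound 1. Also open, going by these compounds, is how an unsubstituted benzyl group would read here.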